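A few compounds are considered here, and "the series" means these few. Any claim that something is new, unique, unknown or untested is made for them only; others in the source may bear on it.

Measured compounds:
compound 1, `NC1=NC2(CCSCC2)N(OCCCOc2cccc(Cl)c2)C(N)=N1`: 130 nM
compound 2, `NC1=NC2(CCOCC2)N(OCCCOc2cc(Cl)c(Cl)cc2Cl)C(N)=N1`: "not determined" (no result reported)
compound 3, `Cc1ccc(OCCCON2C(N)=NC(N)=NC23CCOCC3)cc1`: "not determined" (no result reported)

The series shares one core, a spiro-fused diamino triazine carrying a propoxy linker to an aryl ether. For the measured compounds named here, in a functional assay on MDA-MB-231 cells (Homo sapiens) for antiproliferative activity, read by MTT assay, with a stated time of 72 h (a higher number here means a weaker inhibitor, a lower number a stronger inhibitor), compound 1 gives 130 nM, the only number in the set. For compound 2 the result in this assay is recorded only as "not determined" (no result reported), and for compound 3 the entry in this assay is likewise "not determined" (no result reported), so compound 3 stands without a number, and one further compound, compound 2, is in the same position. Going by the values given here, no step between two measured compounds can therefore be drawn.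

Compound 4, `NC1=NC2(CCOCC2)N(OCCCOc2ccccc2Br)C(N)=N1`, is the next compound to be measured. It differs from compound 3 in one place: 2-bromophenyl in place of 4-methylphenyl on an oxygen on a saturated carbon. Among the compounds with values here, because compound 3 has no value, the size and direction of this step in this assay cannot be anchored; the only reference is compound 1, which carries a different saturated ring and a different halogen pattern on the aryl ether. Compound 4 is expected to fall roughly in the region of compound 1, with a broad range to reflect the missing anchor: its estimated value in this assay is 300 nM, between 50 nM and 2000 nM.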

Compound 4, half-maximal inhibitory concentration: 910 nM
Beside the measured number, compound 4's estimate is 3.0-fold (0.48 log units) below it; measured number inside the range.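

In this assay, for the compounds shown here, compound 4 gives 910 nM and compound 3 has no single number, so no step from compound 3 to compound 4 can be read. No evidence is available that bears on this result. The compounds shown leave open what this assay would show for 2-bromophenyl against 4-methylphenyl on the shared core.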